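The source may hold more compounds than are shown below. What is called first, only, known or untested is meant among the compounds shown, and "the series" means these compounds.

Measured so far in a functional assay on the whole organism (Tail, strain ICR) with Mus musculus as the target, in the tail flick test, with a stated time of 120 min, at a dose of 25 umol/kg by the oral route; a lower number here means a weaker effect, a higher number a stronger effect of the compound at the dose given:
compound 1 `O=C(CN(c1nc(Cl)nc2[nH]cnc12)C1CC1)NCC(=O)OCc1ccccc1` gives 21.7%
compound 2 `O=C(O)CNC(=O)CN(c1nc(Cl)nc2[nH]cnc12)C1CC1` gives 19.8%
compound 3 `O=C(O)CC[C@H](NC(=O)CN(c1nc(Cl)nc2[nH]cnc12)C1CC1)C(=O)O` gives 30.1%

Compound 1 stands second highest of the three numbers. Its nearest neighbour is compound 2, and the two lie within the scatter of each other; compound 3 is furthest from compound 1, but that gap too is within the scatter. Within the data shown here, the only step that goes beyond the scatter is the modest one in a number 10.3 percentage points higher from compound 2 to compound 3 (beyond the scatter), whereas a number 1.9 percentage points lower from compound 1 to compound 2 (within the scatter).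

Compound 4 `NC(=O)CC[C@H](NC(=O)CN(c1nc(Cl)nc2[nH]cnc12)C1CC1)C(=O)OCc1ccccc1` differs from compound 1 in one place: 2-carbamoylethyl in place of hydrogen on a saturated chain carbon bound to an amide-type nitrogen and a carbonyl carbon. Among the measured compounds shown here, the step that bears most on it is the one from compound 2 to compound 3, which also added a group on a saturated chain carbon bound to an amide-type nitrogen and a carbonyl carbon, there a 2-carboxyethyl, and gave a modest rise. The step from compound 1 to compound 2, hydrogen in place of benzyl on an oxygen next to a carbonyl group, stayed within the scatter, so the benzyl present in compound 4 is not expected to alter the picture. For the measured compounds named here, no measured compound carries a 2-carbamoylethyl, so the transfer is uncertain. A small rise is expected for compound 4, a number 6.3 percentage points higher from compound 1 to compound 4 (within the scatter). Compound 4 is estimated at 28%, within a range of 15% to 41%.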

Compound 4, a percentage reported as activity, at one dose (the size of the read-out at that dose, not a potency): 36%
Compound 4: the middle estimate sits 8 percentage points below what was measured, and the stated range covers the measured number.
By their numbers in this assay, from the lowest: compounds 2, 1, 3 and 4 (each within the scatter of the next, the first and the last beyond it).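

In this assay, among these compounds, the new step reads a number 14.3 percentage points higher from compound 1 to compound 4 (beyond the scatter) and shows that a chain on the saturated chain carbon bound to an amide-type nitrogen and a carbonyl carbon can raise the read-out beyond the scatter with the benzyl ester in place, whereas the earlier step of this kind was seen only with the free carboxylic acid. Alongside a number 10.3 percentage points higher from compound 2 to compound 3 (beyond the scatter) there are now two such steps, one with 2-carboxyethyl and one with 2-carbamoylethyl, so among these compounds the rise at this place is not tied to one chain end, and neither step goes against it. Nothing available here explains the rise.

Open, as far as these compounds go, is whether a methyl, a longer chain or a chain ending in an amine on this same carbon would give a step of this kind, and whether the opposite configuration at this carbon would keep it. Also open, from the compounds shown here alone, is whether 2-carbamoylethyl gives the same step when a free carboxylic acid replaces the benzyl ester.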